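The Same Swap Tried on a Second Core

The source may report more compounds than this note shows. Statements on the series, on what has been measured and on what is new or still open speak of the compounds shown alone.

Four compounds built from the same parts are compared here. Compound 1 `Cc1cccc(NNC(=O)c2cccc(NS(=O)(=O)c3cnc(O)nc3O)c2)c1` is tested in a functional assay on OVCAR-3 cells (Homo sapiens) for antiproliferative activity, read by MTT assay, with a stated time of 24 h (a higher number here means a weaker inhibitor, a lower number a stronger inhibitor), and, for compound 1, the result is only a limit of the assay, > 20000 nM. Compound 2 `O=C(NNc1ccccc1Cl)c1cccc(NS(=O)(=O)c2cnc(O)nc2O)c1` differs from it by 2-chlorophenyl in place of 3-methylphenyl on an amine nitrogen, and in this assay compound 2 gives 3350 nM. That change made an at least 5.9-fold lower number from compound 1 to compound 2 (0.77 log units; beyond the scatter); the size can only be bounded due to the limit of > 20000 nM in this assay, at which 2 of the 3 values shown sit.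

Compound 3 `Cc1cccc(NNC(=O)c2ccccc2NS(=O)(=O)c2cnc(O)nc2O)c1` has the same atoms as compound 1 joined differently; the difference between the two cores is not broken down here. In this assay compound 3 also returns only a limit of the assay, > 20000 nM.

Compound 4 `O=C(NNc1ccccc1Cl)c1ccccc1NS(=O)(=O)c1cnc(O)nc1O` is not yet measured. It stands to compound 3 exactly as compound 2 stands to compound 1, by 2-chlorophenyl in place of 3-methylphenyl on an amine nitrogen, and the place of the change reads the same in both cases. For compound 4 the expected step is an at least 3.3-fold lower number from compound 3 to compound 4 (0.52 log units; beyond the scatter), resting on the measured step of an at least 5.9-fold lower number from compound 1 to compound 2 (0.77 log units; beyond the scatter). Compound 4 is therefore estimated at about 6000 nM in this assay, expected to fall between 1500 nM and 20000 nM.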

Compound 4, half-maximal inhibitory concentration: 14100 nM
For compound 4 the middle estimate is 2.4-fold (0.37 log units) below the measured one; low and high end bracket the measured number.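

In this assay, 2-chlorophenyl in place of 3-methylphenyl on the second core gives an at least 1.4-fold lower number from compound 3 to compound 4 (0.15 log units; that floor lies within the scatter). The step points the same way on both cores, but its floor on the second core does not by itself clear the usual scatter, so this is only weak support for the change carrying over, and whether the two steps differ in size is unresolved: the same change on two cores in this assay, an at least 5.9-fold lower number (0.77 log units; beyond the scatter) from compound 1 to compound 2 and an at least 1.4-fold lower number (0.15 log units; that floor lies within the scatter) from compound 3 to compound 4; the limit leaves it open whether they differ Neither step has a known true size, because each starts from a compound that returned only a limit of the assay: the limit of > 20000 nM in this assay, at which 2 of the 4 values shown sit.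

The compounds shown leave open whether the gain belongs to the chlorine or simply to the loss of the methyl group, since each step exchanges one whole group for the other. They also leave open how the two cores would respond to a different group on the same amine nitrogen, such as a methoxyphenyl or a carboxylic acid-bearing phenyl.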